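The compounds below may be only part of what the source reports. "The series", "measured", "known", "first", "only" and "open" are said of these compounds alone.

Of the compounds shown here, two have so far been tested in a functional assay on Malme-3M cells (Homo sapiens) for cytotoxicity, read by sulforhodamine B assay, with a stated time of 48 h, tested at 0.01 uM; on this read-out lower numbers stand for a stronger effect and higher numbers for a weaker effect at the one concentration tested. Compound 1 `COc1cc(C)cc(-c2c(-c3ccnc(-c4ccc(C(C)=O)cc4)c3)cnn2CC#N)c1` gives 93% in this assay, and compound 2 `Cc1cc(O)cc(-c2nn(CC#N)cc2-c2ccnc(-c3ccc(N(C)C)cc3)c2)c1` gives 92% in this assay. These two numbers lie within the usual scatter of each other, so neither compound can be said to act more strongly than the other at the single concentration used; both leave most of the cells growing.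

Compound 3 `COc1cc(C)cc(-c2c(-c3ccnc(-c4ccc(N(C)C)cc4)c3)cnn2CC#N)c1` has not yet been measured. It differs from compound 1 in one place: dimethylamino in place of acetyl on an aromatic carbon. Among the compounds with values here, no pair of measured compounds shows this same exchange, so its effect cannot be read from a direct step. What can be said is that compound 2 already carries the same dimethylamino group and gives 92% in this assay, close to compound 1. The step from compound 1 to compound 3 is therefore expected to be small, a number 1 percentage points lower from compound 1 to compound 3 (within the scatter), not beyond the scatter. Compound 3 is estimated to give 92% in this assay, with a likely range from 82% to 100%.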

Compound 3, a percentage reported as activity, at one concentration (the size of the read-out at that concentration, not a potency): 34%
Compound 3: middle estimate off by 58 percentage points, on the high side; measured number below the stated range.
By their numbers in this assay, from the lowest: compound 3; then compounds 2 and 1 (each within the scatter of the next).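

In this assay, within the data shown here, the exchange of acetyl for dimethylamino, which turns 4-acetylphenyl into 4-(dimethylamino)phenyl, brings a number 59 percentage points lower from compound 1 to compound 3 (beyond the scatter) and gives the first clear step. This position, on an aromatic carbon para to a large group, therefore matters for the effect on these cells, even though both groups have 3 heavy atoms, neither has a ring and neither has a net charge. Nothing shown here explains why this exchange counts for so much.

As far as these compounds go, whether another group at this position, such as a plain amino group or a carboxylic acid, would behave like dimethylamino or like acetyl stays open. The numbers shown come from a single concentration, and how compound 3 behaves at other concentrations is also open.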